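Inverting the hydroxy stereocentre: notes on compound 3

This account rests on a few compounds, and the source may have more. Where it says the series, first, only, none or still open, it means among the compounds named here.

- Compound 1 `Cc1ccccc1-n1nc(-c2c(-c3ccc(F)cc3)nn3c2NCCC3)ccc1=O`: 30 10^-6 cm/s
- Compound 2 `Cc1ccccc1-n1nc(-c2c(-c3ccc(F)cc3)nn3c2NC[C@@H](O)C3)ccc1=O`: 16 10^-6 cm/s
- Compound 3 `Cc1ccccc1-n1nc(-c2c(-c3ccc(F)cc3)nn3c2NC[C@H](O)C3)ccc1=O`: not yet measured

In an ADME assay for permeability, using PAMPA, at pH 6.5 (on this read-out higher numbers stand for higher permeability and lower numbers for lower permeability), compound 2, at 16 10^-6 cm/s, stands within the scatter of compound 1, at 30 10^-6 cm/s. The change to compound 3 is one of configuration only: the two compounds have the same atoms and bonds and differ only in configuration as drawn: 1 of 1 stereo elements differ; a stereocentre at a saturated ring carbon is drawn R in compound 2 and S in compound 3. A stereocentre at a saturated ring carbon is drawn R in compound 2 and S in compound 3. Among the compounds with values here, no measured pair isolates a change of configuration, so the data do not show the size of such a step directly. Within the data shown here, the one measured step that bears on it is a 1.9-fold lower number from compound 1 to compound 2 (0.27 log units; within the scatter), for hydroxy in place of hydrogen on a saturated ring carbon, and it lies within the scatter. No step beyond the scatter is therefore expected in this assay, and no direction is favoured. The expected step is a 1.1-fold higher number from compound 2 to compound 3 (0.05 log units; within the scatter). Compound 3 is estimated at 18 10^-6 cm/s, with an expected range of 9 10^-6 cm/s to 34 10^-6 cm/s.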

Compound 3, apparent permeability: 17 10^-6 cm/s
Beside the measured number, compound 3's estimate is 1.1-fold (0.02 log units) above it, within the range that was stated.
By their numbers in this assay, from the lowest: compounds 2, 3 and 1 (each within the scatter of the next).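

In this assay, the configuration at the saturated ring carbon now has a measured step of its own, a 1.1-fold higher number from compound 2 to compound 3 (0.03 log units; within the scatter), and this step lies within the scatter. It can be read as a step in configuration alone: the fact that compounds 2 and 3 differ only in the configuration as drawn. The second hydroxy compound adds a 1.8-fold lower number from compound 1 to compound 3 (0.25 log units; within the scatter), so hydroxy in place of hydrogen on a saturated ring carbon has now been read in both drawn configurations, and neither step leaves the scatter.

The three compounds shown do not tell what this assay would give with a different group on this carbon, such as a methoxy group, an amine or a carboxylic acid. They also leave open whether the configuration at this carbon would stay within the scatter with any of those groups in place of hydroxy.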